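From 2-bromophenyl to 3-methylphenyl on the shared core

The compounds below may be only part of what the source reports. "The series", "measured", "known", "first", "only" and "open" are said of these compounds alone.

In a functional assay on U2OS cells (Homo sapiens) for cytotoxicity, read by MTT assay, with a stated time of 48 h (a higher number here means a weaker inhibitor, a lower number a stronger inhibitor), compound 1 `Fc1cccc(Nc2nc(-c3cccc(F)c3)nc3ccc(F)cc23)c1` gives 49600 nM as its value. Compound 2 `Fc1cccc(-c2nc(Nc3ccccc3Br)c3cc(F)ccc3n2)c1` stands at > 50000 nM, which is a limit of the assay and not a number. Compound 3 `Cc1cccc(Nc2nc(-c3cccc(F)c3)nc3ccc(F)cc23)c1` keeps the core of compound 2 and carries 3-methylphenyl in place of 2-bromophenyl on a nitrogen on an aromatic ring. For the measured compounds named here, one measured step bears on this change, a number no lower from compound 1 to compound 2 (the limit leaves the size open), which exchanges the group at that same place. The limit leaves the size of that step open, so it gives a direction and no magnitude. Going by the values given here, compound 2 has no number of its own, and the only anchor is compound 1 at 49600 nM, which carries 3-fluorophenyl rather than 2-bromophenyl there. A modest move towards a lower number is therefore expected in this assay, estimated as an at least 1.2-fold lower number from compound 2 to compound 3 (0.09 log units; that floor lies within the scatter), and a second result reported only as a limit remains quite possible. For compound 3 the estimated value is 40000 nM, with an expected range from 18000 nM to 70000 nM as the likely span.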

Compound 3, half-maximal inhibitory concentration: > 50000 nM
Compound 3: only a limit was reported; the forecaster's own chance of this, stated with the estimate: 40%; middle value at least 1.2-fold (0.09 log units) away from the limit.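

Methyl in place of fluoro on an aromatic carbon gives a number no lower from compound 1 to compound 3 (the limit leaves the size open) in this assay, so this second exchange at the same place also brings no lower number than compound 1 has. Compound 3 is reported only as a limit of the assay, as compound 2 was. The step from 2-bromophenyl to 3-methylphenyl cannot be read, and neither can the size of the steps from compound 1, because these results sit at the end of the assay's range: the limit of > 50000 nM in this assay, at which 2 of the 3 values shown sit.

Among the three compounds shown, only compound 1 has a measured number, so they do not show how far a change on this nitrogen can move the value. For the compounds shown here, it remains open whether an aminophenyl or a carboxyphenyl group, or a longer alkyl chain in place of the aromatic ring, would bring a number clearly lower than the one compound 1 gives.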